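The source may hold more compounds than are shown below. What is called first, only, known or untested is meant among the compounds shown, and "the series" means these compounds.

In a functional assay on HL-60 cells (Homo sapiens) for inhibition (on this read-out lower numbers stand for stronger inhibition and higher numbers for weaker inhibition), the measured compounds read as follows.

Compound 1 `COc1ccc(-c2cc(=O)n(Cc3cccnc3)nc2-c2ccc(OC)cc2)cc1`: 430 nM.
Compound 2 `CCn1nc(-c2ccc(OC)cc2)c(-c2ccc(OC)cc2)cc1=O`: 610 nM.
Compound 3 `COc1ccc(-c2cc(=O)n(CC(C)C)nc2-c2ccc(OC)cc2)cc1`: > 100000 nM, which is a limit of the assay and not a number.

Compound 2 gives 610 nM and compound 1 gives 430 nM, two values within the scatter of each other. The next compound, compound 4 `COc1ccc(-c2cc(=O)n(C)nc2-c2ccc(OC)cc2)cc1`, has hydrogen in place of methyl on a saturated chain carbon bound to an aromatic nitrogen, so that ethyl becomes methyl: hydrogen in place of methyl on a saturated chain carbon bound to an aromatic nitrogen.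

All three measured steps act at this same place, but none is this exact change. Pyridin-3-yl gives way to methyl in a 1.4-fold higher number from compound 1 to compound 2 (0.15 log units; within the scatter). The two large steps both lead to compound 3: an at least 230-fold higher number from compound 1 to compound 3 (2.36 log units; beyond the scatter) and an at least 160-fold higher number from compound 2 to compound 3 (2.21 log units; beyond the scatter). The place can therefore be either forgiving or highly sensitive. Those large steps enlarge the group, however, whereas compound 4 trims it, so the closer guide is the small step to compound 2, a 1.4-fold higher number from compound 1 to compound 2 (0.15 log units; within the scatter). A slightly higher number is expected in this assay, with no shift beyond the scatter as the likeliest outcome. The expected change is a 1.5-fold higher number from compound 2 to compound 4 (0.17 log units; within the scatter). For compound 4 the estimated value is 900 nM, with an expected range from 150 nM to 8000 nM.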

Compound 4, half-maximal inhibitory concentration: 1130 nM
Compound 4: the middle estimate sits 1.3-fold (0.10 log units) below what was measured; the range from low to high includes it.
By their numbers in this assay, from the lowest: compounds 1, 2 and 4 (each within the scatter of the next, the first and the last beyond it). At a limit, above all of these: compound 3.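

In this assay, trimming ethyl to methyl stays within the scatter (a 1.9-fold higher number from compound 2 to compound 4 (0.27 log units; within the scatter)), so this position accepts the smallest group shown about as well as it accepts ethyl. Compared with the pyridin-3-yl compound, however, the same small group gives a modest step beyond the scatter (a 2.6-fold higher number from compound 1 to compound 4 (0.42 log units; beyond the scatter)), which shows that the differences among the three active compounds, small as they are, add up to a measurable gap at this position. Compound 3 is held at a limit and not a number, so its step (an at least 88-fold lower number from compound 3 to compound 4 (1.94 log units; beyond the scatter)) is only a bound, and the sharp loss at this position stays confined to the isopropyl group, with the smaller methyl and ethyl ends both well clear of it: the limit of > 100000 nM in this assay, at which 1 of the 4 values shown sits.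

The compounds shown leave open whether a straight propyl chain would behave like ethyl or like the isopropyl compound, and so whether branching or size marks the point of loss. They also leave open whether phenyl in place of pyridin-3-yl, or a chain ending in an amine or a carboxylic acid, would hold the read-out at this position.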